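Aryl Amide in Place of Cyclopropyl Amide on a Shared Core

The compounds below may be only part of what the source reports. "The series", "measured", "known", "first", "only" and "open" are said of these compounds alone.

Compound 1, `Cn1cc(-c2cnc3ccc(N)nc3c2)cn1`: in a functional assay on HeLa cells (Homo sapiens) for antiproliferative activity, read by MTT assay, with a stated time of 48 h (a higher number here means a weaker inhibitor, a lower number a stronger inhibitor), compound 1 gives > 50000 nM, a limit of the assay.
Compound 2, `CC(=O)Nc1ccc2ncc(-c3cnn(C)c3)cc2n1`: in this assay compound 2 gives > 50000 nM, a limit of the assay.
Compound 3, `Cn1cc(-c2cnc3ccc(NC(=O)C4CC4)nc3c2)cn1`: in this assay compound 3 gives > 50000 nM, a limit of the assay.

Compound 3 therefore stands at the limit, and the two other values shown are limits as well; all three sit at the limit of > 50000 nM in this assay, at which 3 of the 3 values shown sit. The step that the two limits leave unreadable from compound 2 to compound 3 cannot be read, nor can a step that the two limits leave unreadable from compound 1 to compound 3 or a step that the two limits leave unreadable from compound 1 to compound 2. Compound 4, `Cn1cc(-c2cnc3ccc(NC(=O)c4ccc(F)cc4)nc3c2)cn1`, has not yet been measured. It differs from compound 3 in that (4-fluorophenyl in place of cyclopropyl on a carbonyl carbon). The measured step that bears on this change is the one on the same carbonyl carbon, a step that the two limits leave unreadable from compound 2 to compound 3, and it gives no size, so no direction of step can be read from the data. With three acyl variants all at the limit, compound 4 is expected to give about 30000 nM in this assay, within a range from 5000 nM to 100000 nM. The expected step is an at least 1.6-fold lower number from compound 3 to compound 4 (0.22 log units; that floor lies within the scatter).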

Compound 4, half-maximal inhibitory concentration: > 50000 nM
Compound 4 ended at the assay's limit; the forecaster's own chance of this, stated with the estimate: 60%; at least 1.6-fold (0.22 log units) between middle value and limit.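

Compound 4 gives > 50000 nM in this assay, which is a limit of the assay, so neither the step from compound 3 to compound 4 nor that from compound 2 to compound 4 can be read: the limit of > 50000 nM in this assay, at which 4 of the 4 values shown sit.

The compounds shown leave open how far each lies from that limit, and whether any acyl group on the shared core changes the read-out at all.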